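The source may report more compounds than this note shows. Statements on the series, on what has been measured and on what is new or still open speak of the compounds shown alone.

Measured so far in a functional assay on HEK293 cells for positive allosteric modulation of metabotropic glutamate receptor 5 (Homo sapiens), read by FLIPR and calcium flux; on this read-out higher numbers stand for an effect only at larger amounts of compound and lower numbers for an effect already at smaller amounts:
compound 1 `O=C(COCc1ncccn1)N1CCN(c2ccc(Cl)cc2Cl)CC1`, 18000 nM
compound 2 `O=C(CCCc1ccncc1)N1CCN(c2ccc(Cl)cc2Cl)CC1`, 5300 nM
compound 3 `O=C(CNCc1ccncc1)N1CCN(c2ccc(Cl)cc2Cl)CC1`, 8500 nM

Compound 3 has the second highest of the three numbers; its nearest neighbour is compound 2, with a 1.6-fold higher number from compound 2 to compound 3 (0.21 log units; within the scatter), and the furthest is compound 1, with a 2.1-fold lower number from compound 1 to compound 3 (0.33 log units; beyond the scatter). Compound 4 `O=C(CSc1ccccc1)N1CCN(c2ccc(Cl)cc2Cl)CC1` carries phenylsulfanyl in place of ((pyridin-4-yl)methyl)amino on a saturated chain carbon bound to a carbonyl carbon. Going by the values given here, no measured step swaps the group on this carbon for one without a ring nitrogen or a donor; the known steps, a 3.4-fold lower number from compound 1 to compound 2 (0.53 log units; beyond the scatter) and a 2.1-fold lower number from compound 1 to compound 3 (0.33 log units; beyond the scatter), were modest, and a 1.6-fold higher number from compound 2 to compound 3 (0.21 log units; within the scatter) stayed within the scatter. Compound 4 is therefore expected to show a 1.4-fold lower number from compound 3 to compound 4 (0.15 log units; within the scatter), a change not clearly beyond the scatter. The estimate for compound 4 is 6000 nM, ranging from 2000 nM to 20000 nM.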

Compound 4, half-maximal effective concentration: > 25000 nM
Compound 4: no number, only a limit (the forecaster's own chance of this, stated with the estimate: 15%); middle value at least 4.1-fold (0.61 log units) from the limit.
By their numbers in this assay, from the lowest: compounds 2 and 3 (each within the scatter of the next); then compound 1. At a limit, above all of these: compound 4.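

In this assay compound 4 gives no number, only a limit: the limit of > 25000 nM in this assay, at which 1 of the 4 values shown sits. On this saturated chain carbon bound to a carbonyl carbon, phenylsulfanyl is the only group shown with a carbon-only ring, and it brings an at least 2.9-fold higher number from compound 3 to compound 4 (0.46 log units; beyond the scatter) and an at least 4.7-fold higher number from compound 2 to compound 4 (0.67 log units; beyond the scatter). Compound 1 goes against a clean separation of the carbon-only ring from the groups with ring nitrogens, since an at least 1.3-fold higher number from compound 1 to compound 4 (0.14 log units; that floor lies within the scatter).

The compounds shown leave open whether the sulfur, the carbon-only ring or the lost donor matters. A (pyridin-4-yl)sulfanyl group or a benzylamino group would separate these.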